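Dropping a methoxy group from a benzyloxy ketone

The source may report more compounds than this note shows. Statements on the series, on what has been measured and on what is new or still open speak of the compounds shown alone.

Of the compounds shown here, two have been tested so far in a functional assay on HCT-116 cells (Homo sapiens) for antiproliferative activity, read by sulforhodamine B assay, with a stated time of 3 days, tested at 25 uM; on this read-out higher numbers stand for a stronger effect at the one concentration tested and lower numbers for a weaker effect. Compound 1, `O=C(/C=C/c1ccc(OCc2ccccc2)cc1)c1ccccc1`, gives 52.3% in this assay. Compound 2, `COc1cccc(/C=C/C(=O)c2ccc(OCc3ccccc3)cc2)c1`, gives 35.4% in this assay, the lowest of the two numbers; its nearest neighbour is compound 1, which stands higher by a margin that lies beyond the scatter. Among the compounds with values here, no pair of measured compounds differs in a single place, so no measured step is available to lean on.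

Compound 3, `O=C(/C=C/c1ccccc1)c1ccc(OCc2ccccc2)cc1`, has not yet been measured. It differs from compound 2 in one place: hydrogen in place of methoxy on an aromatic carbon. The change removes a methoxy group from an aromatic carbon of a six-membered aromatic ring of carbon only, leaving hydrogen there, so that a 3-methoxyphenyl group becomes a plain phenyl group, while the benzyloxy group and the rest of the shared core stay as they are.

With nothing else to go on, the step from compound 2 to compound 3 is expected to be small and is estimated as a number 4.6 percentage points higher from compound 2 to compound 3 (within the scatter), possibly within the scatter. For compound 3, a value of 40% is estimated in this assay, with an expected range from 20% to 60%.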

Compound 3, a percentage reported as inhibition, at one concentration (the size of the read-out at that concentration, not a potency): 24.3%
For compound 3 the middle estimate is 15.7 percentage points above the measured one, and the stated range covers the measured number.
By their numbers in this assay, from the lowest: compound 3; then compound 2; then compound 1.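

In this assay, within the data shown here, the first comparison that differs in one place shows that this aromatic carbon is not indifferent to what it carries: replacing methoxy with hydrogen, so that 3-methoxyphenyl becomes phenyl, gives a number 11.1 percentage points lower from compound 2 to compound 3 (beyond the scatter) while the benzyloxy group and the rest of the shared core stay as they are. The step is modest but beyond the scatter, and it shows that, for this pair, the compound carrying the methoxy group has the larger read-out at the one concentration tested. Nothing available bears on why the read-out moves in this way, and the step stands as an observation only.

Going by these compounds, it remains open whether this difference is particular to methoxy or would also appear with other groups on the same aromatic carbon, such as hydroxy, fluorine, ethoxy or an amine. One pair also cannot show whether methoxy would have a step of similar size or direction on other carbons of this ring, or on a different core.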